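Fluoro Added Beside the Lactam: An Expectation

A few compounds are considered here, and "the series" means these few. Any claim that something is new, unique, unknown or untested is made for them only; others in the source may bear on it.

Measured compounds:
compound 1, `Cc1ccc(Nc2nc(N)nc(COc3cccc(N4CCCC4=O)c3)n2)cc1Cl`: 820 nM
compound 2, `Cc1ccc(Nc2nc(N)nc(COc3cccc(N4CCCCC4=O)c3)n2)cc1Cl`: 22400 nM

Both compounds were tested in an assay on COS-7 cells for agonist activity at Free fatty acid receptor 1 (Homo sapiens), read by scintillation counting and inositol phosphate accumulation, with a stated time of 90 min; a lower number here means that less compound is needed, a higher number that more compound is needed for the effect. Compound 1 holds the lowest of the two numbers; its nearest neighbour is compound 2, and the step of a 27-fold higher number from compound 1 to compound 2 (1.44 log units; beyond the scatter) shows how sharply the read-out reacts to a change at the lactam side of the aryl ether ring.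

The unmeasured compound 3, `Cc1ccc(Nc2nc(N)nc(COc3cccc(N4CCCC4=O)c3F)n2)cc1Cl`, keeps the 2-oxopyrrolidin-1-yl group of compound 1 and differs only in fluoro in place of hydrogen on an aromatic carbon. Among the compounds with values here, no measured step bears directly on this change: the single known step swaps one lactam ring for another, while here the lactam is retained and a fluoro enters on the aromatic carbon of a six-membered aromatic ring of carbon only, ortho to the 2-oxopyrrolidin-1-yl group. One fluorine atom is a small addition, so the expected step of a 1.1-fold higher number from compound 1 to compound 3 (0.04 log units; within the scatter) is small, with no direction claimed beyond the scatter. Compound 3 is therefore estimated at 900 nM in this assay, with a range from 300 nM to 3000 nM.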

Compound 3, half-maximal effective concentration: 14100 nM
Compound 3: middle estimate off by 16-fold (1.19 log units), on the low side; measured number above the stated range.
By their numbers in this assay, from the lowest: compound 1; then compounds 3 and 2 (each within the scatter of the next).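

In this assay, one fluoro on the aromatic carbon ortho to a 2-oxopyrrolidin-1-yl group gives a 17-fold higher number from compound 1 to compound 3 (1.24 log units; beyond the scatter), even though the lactam itself stays unchanged. The earlier step, a 27-fold higher number from compound 1 to compound 2 (1.44 log units; beyond the scatter), showed only that the read-out reacts to a change of the lactam ring; this new step shows that it also reacts strongly to a change of one heavy atom on the aromatic ring that carries the lactam, so the small size of a change says little about the size of its step here. The data shown offer no measurement that explains why this single atom matters so much.

The compounds shown leave open whether this rise in the number belongs to fluoro alone or would also follow from another group on the same carbon, such as a methyl, a chlorine or a methoxy, and whether a fluoro on the other carbons of this ring would give a step of similar size. They also leave open how the same fluoro would act alongside the 2-oxopiperidin-1-yl group of compound 2.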